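Hydroxy for methyl on the shared core

A few compounds are considered here, and "the series" means these few. Any claim that something is new, unique, unknown or untested is made for them only; others in the source may bear on it.

In a functional assay on V79 cells (Cricetulus griseus) for cytotoxicity, read by colony formation (a higher number here means a weaker inhibitor, a lower number a stronger inhibitor), compound 3 (`Cc1c(F)c(N2CCC(N)C2)cc2c1c(=O)c(C(=O)O)cn2C1CC1`) gives 14 ug/mL. Compound 2 (`NC1CCN(c2c(F)cc3c(=O)c(C(=O)O)cn(C4CC4)c3c2C(F)(F)F)CC1`) gives 20 ug/mL, which lies within the usual scatter of compound 3, so the two numbers stand level.

Compound 1 (`CCNCC1CCN(c2cc3c(cc2F)c(=O)c(C(=O)O)cn3NC)C1`) is reported only as a limit, > 500 ug/mL.

The next compound to be read is compound 4 (`NC1CCN(c2cc3c(c(O)c2F)c(=O)c(C(=O)O)cn3C2CC2)C1`). Compared with compound 3, it has hydroxy in place of methyl on an aromatic carbon, ortho to a fluoro group and ortho to a fused ring: hydroxy in place of methyl on an aromatic carbon.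

Within the data shown here, no pair of measured compounds in this set differs in one place, so this assay offers no direct precedent for this swap. The expectation therefore starts from compound 3 at 14 ug/mL and carries a wide margin. The estimated change, a 2.5-fold higher number from compound 3 to compound 4 (0.40 log units; beyond the scatter), is a modest move toward a higher number, meaning a somewhat weaker inhibitor, although a result within the scatter of compound 3 would not be surprising. For compound 4 the expected value is 35 ug/mL, with an estimated range of 10 ug/mL to 150 ug/mL.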

Compound 4, half-maximal inhibitory concentration: 72 ug/mL
The estimate for compound 4 lay 2.1-fold (0.31 log units) below the measured number; the measured number falls inside the stated range.
By their numbers in this assay, from the lowest: compounds 3 and 2 (each within the scatter of the next); then compound 4. At a limit, above all of these: compound 1.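

In this assay, among these compounds, this is the first comparison of compounds that differ in one place: hydroxy in place of methyl on an aromatic carbon, ortho to a fluoro group and ortho to a fused ring, gives a 5.1-fold higher number from compound 3 to compound 4 (0.71 log units; beyond the scatter) and so marks a somewhat weaker inhibitor. The position therefore responds to this change, a step beyond the scatter from swapping only one heavy atom, although that reading rests on this single pair and sets no pattern for the series. The measurements shown offer nothing that accounts for the size or direction of this step.

Still open, from the compounds shown here alone, is how an amine or a methoxy group at this same aromatic carbon would read against methyl and hydroxy on the shared core. Also open, going by these compounds, is whether hydroxy in place of methyl gives a step of similar size when a different amine stands in place of the 3-aminopyrrolidin-1-yl group, since only this one substituent accompanies the swap here.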